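Diaminoquinazoline series: heteroaryl substituent at the imidazole position

The source may hold more compounds than are shown below. What is called first, only, known or untested is meant among the compounds shown, and "the series" means these compounds.

Measured compounds in an assay on isolated protein for inhibition of Dihydrofolate reductase (Homo sapiens), read by spectrophotometry, using NADPH, with a stated time of 10 min; a lower number here means a stronger inhibitor, a higher number a weaker inhibitor:
compound 1 `Cc1cc2ncn(-c3ccc4c(N)nc(N)nc4c3)c2cc1C` — 1610 nM
compound 2 `Cc1cc2nc(-c3cncn3C)n(-c3ccc4c(N)nc(N)nc4c3)c2cc1C` — 2920 nM
compound 3 `Cc1cc2nc(-c3cccn3C)n(-c3ccc4c(N)nc(N)nc4c3)c2cc1C` — > 5000 nM

Compound 3 stands weakest of the three on what is shown, and its value is a limit of this assay, not a number (the limit of > 5000 nM in this assay, at which 1 of the 3 values shown sits). Compound 4 `Cc1cc2nc(-c3ccncc3)n(-c3ccc4c(N)nc(N)nc4c3)c2cc1C` differs from compound 3 by pyridin-4-yl in place of 1-methyl-1H-pyrrol-2-yl on an aromatic carbon.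

Among the measured compounds shown here, no measured step introduces pyridin-4-yl. The nearest are the additions to the shared core: a 1.8-fold higher number from compound 1 to compound 2 (0.26 log units; within the scatter) and an at least 3.1-fold higher number from compound 1 to compound 3 (0.49 log units; beyond the scatter), and the exchange an at least 1.7-fold higher number from compound 2 to compound 3 (0.23 log units; that floor lies within the scatter). The smaller of the two five-membered groups added to compound 1 thus stayed within the scatter, while the pyrrolyl fell beyond it. A six-membered ring with one nitrogen is outside the range covered, so the direction is uncertain; a modest improvement relative to compound 3 is expected in this assay, an at least 1.2-fold lower number from compound 3 to compound 4 (0.09 log units; that floor lies within the scatter), with a real chance the reading is again only a limit.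

Compound 4 is expected to give about 4000 nM in this assay, within 1500 nM to 12000 nM.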

Compound 4, inhibition constant: 437 nM
Compound 4: middle estimate off by 9.2-fold (0.96 log units), on the high side; measured number outside the range, below it.
By their numbers in this assay, from the lowest: compound 4; then compounds 1 and 2 (each within the scatter of the next). At a limit, above all of these: compound 3.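

In this assay, adding pyridin-4-yl to the shared core gives a 3.7-fold lower number from compound 1 to compound 4 (0.57 log units; beyond the scatter), making it the only substituent shown at this position that lowers the number. The exchanges from the five-membered groups give a 6.7-fold lower number from compound 2 to compound 4 (0.82 log units; beyond the scatter) and an at least 11-fold lower number from compound 3 to compound 4 (1.05 log units; beyond the scatter); since 1-methyl-1H-pyrrol-2-yl and pyridin-4-yl match in heavy atoms, donors and acceptors as counted, those counts do not separate the pair, while ring size and the methyl group do differ. Compound 3 is a limit of the assay and not a number, so its step is only a floor: the limit of > 5000 nM in this assay, at which 1 of the 4 values shown sits.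

Going by these compounds, whether the gain follows the six-membered ring or its nitrogen stays open, and phenyl or pyridin-3-yl at this position would separate the two. How far a substituent on the pyridine ring, such as an amine, would move the number is also unknown.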